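Mirror-image pair in the pyrrolidine amide series

The compounds below may be only part of what the source reports. "The series", "measured", "known", "first", "only" and "open" are said of these compounds alone.

Of the compounds shown here, two have numbers so far. Compound 1 `N#Cc1ccc(N2CCN(Cc3cn4cc(Cl)ccc4n3)CC2)nc1` gives, in a functional assay on CHO-K1 cells for agonist activity at G-protein coupled receptor 39 (Homo sapiens), read by cAMP accumulation, with stated times of 30 min and 60 min (on this read-out lower numbers stand for an effect already at smaller amounts and higher numbers for an effect only at larger amounts of compound), a value of 12000 nM. Compound 2 `CCc1nc(CN2C[C@H](C(=O)NCc3ccccc3Cl)[C@@H](c3cccnc3)C2)c[nH]1` gives in this assay a value of 310 nM, the lowest of the two numbers; the gap from compound 1 to compound 2 is wide and lies well beyond the usual scatter of repeated measurements. The two share no common scaffold, so nothing about single structural changes can be read from that pair.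

Compound 3 `CCc1nc(CN2C[C@@H](C(=O)NCc3ccccc3Cl)[C@H](c3cccnc3)C2)c[nH]1` is the unmeasured partner of compound 2. The change is the two compounds have the same atoms and bonds and differ only in configuration as drawn: 2 of 2 stereo elements differ (all stereocentres are inverted: mirror images); a stereocentre at a saturated ring carbon is drawn R in compound 2 and S in compound 3; a stereocentre at a saturated ring carbon is drawn S in compound 2 and R in compound 3. Among the measured compounds shown here, no step between measured compounds of this kind is available, so the size of the effect of inverting both centres rests on the general behaviour of mirror-image pairs rather than on anything measured here. For such pairs the two partners usually differ by a step well beyond the scatter, and the partner with the lower number is more often the one already measured. Compound 3 is therefore expected to give a higher number in this assay, estimated at 3000 nM with a range from 300 nM to 30000 nM. The expected step from compound 2 to compound 3 is a 9.7-fold higher number from compound 2 to compound 3 (0.99 log units; beyond the scatter), with the range left deliberately wide.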

Compound 3, half-maximal effective concentration in the G-protein coupled receptor 39 assay: 840 nM
Compound 3: middle estimate off by 3.6-fold (0.55 log units), on the high side, and the stated range covers the measured number.
By their numbers in the G-protein coupled receptor 39 assay, from the lowest: compound 2; then compound 3; then compound 1.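

Among the compounds shown here, in the G-protein coupled receptor 39 assay, inverting both ring stereocentres gives a 2.7-fold higher number from compound 2 to compound 3 (0.43 log units; beyond the scatter), the first step that can be read at a single change, and the effect survives the inversion, with compound 3 still at 840 nM. This modest step can be assigned to configuration alone, and the ground for that is: the fact that compounds 2 and 3 differ only in the configuration as drawn. In a physicochemical assay for permeability (a lower number here means that the compound crosses the layer more slowly, a higher number that the compound crosses the layer faster), the same inversion gives a 1.5-fold lower number from compound 2 to compound 3 (0.18 log units; within the scatter), so the mirror images are not separated on this read-out, with compound 2 at 1.2 10^-6 cm/s and compound 3 at 0.8 10^-6 cm/s.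

How the step in the G-protein coupled receptor 39 assay divides between the two stereocentres remains open, since the pair shown changes both at once. Also open, on these data alone, is whether the same order between mirror images holds with a longer chain or a cyclopropyl group in place of the ethyl group.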